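Trimming One Methoxy Group From Compound 2

This account rests on a few compounds, and the source may have more. Where it says the series, first, only, none or still open, it means among the compounds named here.

Of the compounds shown here, three sharing one core have been measured in a functional assay on HCC 2998 cells (Homo sapiens) for inhibition, read by sulforhodamine B assay, with a stated time of 48 h; a higher number here means a weaker inhibitor of growth, a lower number a stronger inhibitor of growth. Compound 1, `CCOC(=O)[C@H](CCC(=O)O)NC(=O)c1ccc(CNc2nc3cc(N)cc(N)c3nc2-c2ccccc2)cc1`, is reported only as a limit of the assay, < 100000 nM. Compound 3, `CCOC(=O)[C@H](CCC(=O)O)NC(=O)c1ccc(Sc2nc3cc(N)cc(N)c3nc2-c2ccccc2)cc1`, gives 17000 nM. Compound 2, `COc1ccc(CNc2nc3cc(N)cc(N)c3nc2-c2ccccc2)cc1OC`, gives 56200 nM, the highest of the two numbers available; its nearest neighbour is compound 3, whose number is lower by a margin beyond the usual scatter.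

Compound 4, `COc1ccc(CNc2nc3cc(N)cc(N)c3nc2-c2ccccc2)cc1`, has not yet been measured. It differs from compound 2 by a single change: hydrogen in place of methoxy on an aromatic carbon, turning a 3,4-dimethoxyphenyl into a 4-methoxyphenyl. Going by the values given here, no measured pair in this set shows the same change, so there is no direct precedent to lean on. Removing two heavy atoms in this way is expected to move the number in this assay little, with no step beyond the scatter as the most likely outcome. Compound 4 is therefore expected to give about 60000 nM, most plausibly between 20000 nM and 180000 nM, which corresponds to an expected step of a 1.1-fold higher number from compound 2 to compound 4 (0.03 log units; within the scatter).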

Compound 4, concentration for total growth inhibition: 51300 nM
The estimate for compound 4 lay 1.2-fold (0.07 log units) above the measured number; the measured number falls inside the stated range.
By their numbers in this assay, from the lowest: compound 3; then compounds 4 and 2 (each within the scatter of the next).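

In this assay, taking one methoxy group off the 3,4-dimethoxyphenyl to leave a 4-methoxyphenyl gives a 1.1-fold lower number from compound 2 to compound 4 (0.04 log units; within the scatter), so hydrogen and methoxy cannot be told apart at this position. Going by these compounds alone, this is the first step in the set that isolates a single change, and it shows that this methoxy group is not needed to keep the number of compound 2 in this assay. Compound 1 offers no number for comparison, only a limit: the limit of < 100000 nM in this assay, at which 1 of the 4 values shown sits.

As far as these compounds go, whether the remaining methoxy group matters stays open, as does whether an amine or a carboxylic acid at the position now holding hydrogen would shift the number. Compound 3 differs from compound 4 in more than one place, so that pair cannot show which change matters.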